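Adding a Hydroxy Group to a Weak Nucleoside Analog

This account rests on a few compounds, and the source may have more. Where it says the series, first, only, none or still open, it means among the compounds named here.

Measured compounds:
- compound 1, `Cc1cccc(CNc2ncnc3c2ncn3[C@@H]2O[C@H](CO)[C@@H](O)[C@H]2O)c1`: > 166000 nM
- compound 2, `COc1cccc(CNc2ncnc3c2ncn3[C@@H]2O[C@H](CO)[C@@H](O)[C@H]2O)c1O`: 20200 nM

Compound 1 carries a 3-methylphenyl group on a saturated chain carbon bound to a nitrogen of the shared core. In a functional assay on MCF cells (Homo sapiens) for antiproliferative activity, with a stated time of 72 h (a lower number here means a stronger inhibitor, a higher number a weaker inhibitor), compound 1 gives only a limit, > 166000 nM, which is the edge of what the assay reports rather than a number, as the limit of > 166000 nM in this assay, at which 1 of the 2 values shown sits, shows. Compound 2 replaces that group with 2-hydroxy-3-methoxyphenyl and gives 20200 nM in this assay, a step of an at least 8.2-fold lower number from compound 1 to compound 2 (0.91 log units; beyond the scatter).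

The unmeasured compound 3, `Cc1cccc(CNc2ncnc3c2ncn3[C@@H]2O[C@H](CO)[C@@H](O)[C@H]2O)c1O`, differs from compound 1 by hydroxy in place of hydrogen on an aromatic carbon. Compound 3 thus shares the hydroxy of compound 2 but keeps the methyl of compound 1. For the measured compounds named here, the only step bearing on it is an at least 8.2-fold lower number from compound 1 to compound 2 (0.91 log units; beyond the scatter), where the hydroxy entered together with a methoxy in place of methyl; a gain of similar size, though less certain, is expected here. The estimate for compound 3 is 35000 nM, within 12000 nM to 120000 nM, which would mean an at least 4.7-fold lower number from compound 1 to compound 3 (0.67 log units; beyond the scatter), an expected gain.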

Compound 3, half-maximal inhibitory concentration: 6900 nM
Estimate against measurement, compound 3: 5.1-fold (0.71 log units) above; the whole stated range lies above it.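

Compound 2 brought in its hydroxy together with a methoxy in place of methyl, so the share of the hydroxy alone could not be read from it. Compound 3 separates the two changes: in this assay, hydroxy in place of hydrogen on an aromatic carbon, ortho to a methyl group, gives an at least 24-fold lower number from compound 1 to compound 3 (1.38 log units; beyond the scatter), a large gain from a single added oxygen atom. With the hydroxy present, the methoxy is not needed for this gain, as the comparison of the two hydroxy compounds shows a 2.9-fold lower number from compound 2 to compound 3 (0.47 log units; beyond the scatter), so among these three compounds the methyl form is the stronger one.

On these data alone, whether the hydroxy itself matters at this place, or any group there would do, stays open, and an amine or a methoxy in the same position, on the 3-methylphenyl group, would be needed to tell these apart. The full size of the hydroxy step also stays open, as the value of compound 1 is a limit and not a number, so the step gives only a minimum: the limit of > 166000 nM in this assay, at which 1 of the 3 values shown sits.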